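The compounds below may be only part of what the source reports. "The series", "measured", "known", "first", "only" and "open" are said of these compounds alone.

Compound 1 `COc1cc(NCc2scnc2C)ccc1-c1cnco1` was examined in an ADME assay on Huh-7 cells (Homo sapiens) for cytotoxicity, read by MTT assay, with a stated time of 96 h; a lower number here means that less compound is tolerated, a higher number that more compound is tolerated. In this assay, among the compounds with values here, compound 1 gives 58500 nM, the only plain number among the values at hand. Compound 2 `COc1cc(/N=C/c2cccs2)ccc1-c1cnco1` was also tested, and in this assay compound 2 gives > 100000 nM, which is a limit of the assay rather than a number. Compound 1 therefore stands alone as a measured figure, while the other reading sits at the limit of > 100000 nM in this assay, at which 1 of the 2 values shown sits. Compound 3 `COc1cc(NCc2ccncc2)ccc1-c1cnco1` remains to be measured in this assay. It differs from compound 1 in one place: pyridin-4-yl in place of 4-methyl-1,3-thiazol-5-yl on a saturated chain carbon bound to a nitrogen on an aromatic ring. Within the data shown here, no step between two measured compounds is available, so this change has no direct precedent here. Compound 3 is expected to be tolerated at roughly the level of compound 1, with the expected step being a 1.2-fold higher number from compound 1 to compound 3 (0.08 log units; within the scatter), within or barely beyond the usual scatter. Compound 3 is thus estimated at 70000 nM, with a range from 30000 nM to 150000 nM.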

Compound 3, half-maximal cytotoxic concentration: 72200 nM
The estimate for compound 3 lay 1.0-fold (0.01 log units) below the measured number; measured number inside the range.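

On the saturated chain carbon bound to a nitrogen on an aromatic ring, pyridin-4-yl in place of 4-methyl-1,3-thiazol-5-yl gives in this assay a 1.2-fold higher number from compound 1 to compound 3 (0.09 log units; within the scatter). This first step at the position shows that a six-membered aromatic ring with 1 hetero atom can replace a five-membered aromatic ring with 2 hetero atoms, with the sulfur leaving, and the result stays within the usual scatter. Compound 2 remains the only limit rather than a plain number: the limit of > 100000 nM in this assay, at which 1 of the 3 values shown sits.

A single pair cannot show whether this tolerance extends to groups of another kind at the same place, such as a carboxylic acid or a saturated amine. Compound 2 differs from compound 1 in more than one place, so its limit says nothing about this change.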